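The source may hold more compounds than are shown below. What is called first, only, known or untested is meant among the compounds shown, and "the series" means these compounds.

Three compounds share a core in which a carbonyl, an exocyclic double bond and a sulfur-bearing group meet on one chain carbon, and each was tested in a functional assay on DU-145 cells (Homo sapiens) for inhibition, read by trypan blue exclusion, with a stated time of 96 h; a lower number here means a stronger inhibitor of growth, a higher number a weaker inhibitor of growth. Compound 1 `O=C(/C(=C\c1c(O)cc(O)cc1O)S(=O)(=O)c1ccccc1Br)c1ccc(Cl)cc1` gives 50000 nM in this assay. Compound 3 `O=C(/C(=C\c1c(O)cc(O)cc1O)S(=O)(=O)c1ccccc1Br)c1ccc(Br)cc1` gives 50000 nM in this assay, and the step of no change at the digits printed from compound 1 to compound 3 (within the scatter) shows that swapping one halogen for another on that aromatic carbon leaves the number where it was. Compound 2 `O=C(/C(=C\c1ccc(F)cc1)S(=O)(=O)c1ccc(Br)cc1)c1ccc(Br)cc1` gives 4000 nM in this assay; it differs from compound 1 in more than one place, so its lower number cannot be tied to any single change. Among the three, compound 1 thus sits at the high end, level with compound 3 and well apart from compound 2.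

Compound 4 `O=C(/C(=C\c1c(O)cc(O)cc1O)SCc1ccc(Cl)cc1Cl)c1ccc(Cl)cc1` is not yet measured. It differs from compound 1 by (2,4-dichlorobenzyl)sulfanyl in place of (2-bromophenyl)sulfonyl on a double-bonded chain carbon bound to a carbonyl carbon and a double-bonded chain carbon. Among the compounds with values here, no measured step touches this part of the molecule, so no step size can be read across from the data. Compound 4 is therefore expected to stay near compound 1, with the estimate a 1.7-fold lower number from compound 1 to compound 4 (0.22 log units; within the scatter) in this assay carrying a wide range. The expected value for compound 4 is 30000 nM, somewhere between 5000 nM and 60000 nM.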

Compound 4, concentration for 50% growth inhibition: 25000 nM
Compound 4: middle estimate off by 1.2-fold (0.08 log units), on the high side; the measured number falls inside the stated range.
By their numbers in this assay, from the lowest: compound 2; then compounds 4, 1 and 3 (each within the scatter of the next).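

Within the data shown here, this is the first look at the group on the double-bonded chain carbon bound to a carbonyl carbon, since the earlier step changed only a halogen on an aromatic carbon elsewhere in the molecule. In this assay, putting (2,4-dichlorobenzyl)sulfanyl in place of (2-bromophenyl)sulfonyl gives a 2.0-fold lower number from compound 1 to compound 4 (0.30 log units; within the scatter), so this substantial exchange, which removes both sulfonyl oxygens and replaces the bromine with two chlorines, does not move the number beyond the usual scatter of the assay. No separate measurement is available to explain this result.

The exchange alters the sulfur group, the link to the ring and the ring's halogens all at once, so the compounds shown cannot separate these changes; a (2,4-dichlorobenzyl)sulfonyl group at this position would test the sulfur group alone. As far as these compounds go, it also remains open whether a quite different group here, such as a primary amine or a carboxylic acid, would shift the number beyond the scatter from the level of compound 1 and compound 4.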